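A few compounds are considered here, and "the series" means these few. Any claim that something is new, unique, unknown or untested is made for them only; others in the source may bear on it.

Compound 1 `COc1ccc(-c2sccc2-c2cc(OC)c(OC)c(OC)c2)cc1` gives 5470 nM.
Compound 2 `COc1ccc(-c2sccc2-c2cc(OC)c(OC)c(OC)c2)cc1[N+](=O)[O-]` gives 3310 nM.
Compound 3 `CCOC(=O)c1cc(-c2ccc(OC)cc2)c(-c2cc(OC)c(OC)c(OC)c2)s1` gives 6820 nM.

All three numbers come from a functional assay on SGC-7901 cells (Homo sapiens) for antiproliferative activity, read by MTT assay, with a stated time of 72 h; on this read-out higher numbers stand for weaker inhibition and lower numbers for stronger inhibition. Compound 1 and compound 2 share one core and differ in a single place: nitro in place of hydrogen on an aromatic carbon. That change produced a 1.7-fold lower number from compound 1 to compound 2 (0.22 log units; within the scatter). Compound 3 rests on a different core; the difference between the two cores is not broken down here. Compound 3 and compound 1 give numbers within the usual scatter of each other, while compound 3 and compound 2 lie beyond it.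

Compound 4 `CCOC(=O)c1cc(-c2ccc(OC)c([N+](=O)[O-])c2)c(-c2cc(OC)c(OC)c(OC)c2)s1` has not yet been measured. It differs from compound 3 by nitro in place of hydrogen on an aromatic carbon, the same change, at a place described in the same words as before. For compound 4 the expected step is a 1.6-fold lower number from compound 3 to compound 4 (0.21 log units; within the scatter), resting on the earlier step of a 1.7-fold lower number from compound 1 to compound 2 (0.22 log units; within the scatter). Compound 4 is therefore estimated to give 4200 nM in this assay, most likely between 2200 nM and 8500 nM.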

Compound 4, half-maximal inhibitory concentration: 19400 nM
For compound 4 the middle estimate is 4.6-fold (0.66 log units) below the measured one; the whole stated range lies below it.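

Placing a nitro group on the core of compound 3 gave a 2.8-fold higher number from compound 3 to compound 4 (0.45 log units; beyond the scatter) in this assay. The step seen on the core of compound 1 therefore did not carry over to this second core, and the same change behaved differently on the two cores: the same change on two cores in this assay, a 1.7-fold lower number (0.22 log units; within the scatter) from compound 1 to compound 2 and a 2.8-fold higher number (0.45 log units; beyond the scatter) from compound 3 to compound 4, 4.7-fold (0.67 log units) apart, beyond the scatter of two such steps. Among these compounds, this shows that the outcome of this change depends on the core, but with only one pair on each core, it does not show what in the cores produces the difference.

Going by these compounds, it remains open whether the ester group of compound 3 is the part of its core that matters, which a carboxylic acid in its place could test. On these data alone, it is also open whether an amine in place of the nitro group would differ between the two cores in the same way.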